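Amide nitrogen substituent change on the shared core

A few compounds are considered here, and "the series" means these few. Any claim that something is new, unique, unknown or untested is made for them only; others in the source may bear on it.

Compound 1 `CN1CCCC(NS(=O)(=O)c2ccccc2Nc2cc(-c3ccc4ccn(C)c4c3)c3nccnc3c2)C1` and compound 2 `Cn1ccc2ccc(-c3cc(Nc4ccccc4S(=O)(=O)NCC4CCOCC4)cc4nccnc34)cc21` carry sulfonamide-linked amines on the shared core. In an ADME assay on microsomes from liver (Mus musculus, strain CD-1) for metabolic stability, read by LC-MS, tested at 2 uM (on this read-out higher numbers stand for a longer-lived compound and lower numbers for a shorter-lived compound), compound 1 gives 0.483 h and compound 2 gives 0.3 h; the move from (oxan-4-yl)methyl to 1-methylpiperidin-3-yl on a sulfonamide nitrogen is a 1.6-fold lower number from compound 1 to compound 2 (0.21 log units; within the scatter). Compound 3 `Cn1ccc2ccc(-c3cc(Nc4cnccc4C(=O)NC4CCNC(=O)C4)cc4nccnc34)cc21` is amide-linked. In this assay compound 3 reports only a limit, > 1 h, so it sits at the limit of > 1 h in this assay, at which 1 of the 3 values shown sits, without a number. Compound 4 `CN1CCC(CNC(=O)c2ccncc2Nc2cc(-c3ccc4ccn(C)c4c3)c3nccnc3c2)C1` differs from compound 3 by (1-methylpyrrolidin-3-yl)methyl in place of 2-oxopiperidin-4-yl on an amide-type nitrogen. Among the compounds with values here, the one measured step concerns a sulfonamide nitrogen and other groups, so it bears little on this amide change, and it is within the scatter anyway. The step of an at least 1.1-fold lower number from compound 3 to compound 4 (0.04 log units; that floor lies within the scatter) is expected to stay within the scatter. Compound 4 is estimated at 0.9 h, with a range of 0.4 h to 2 h.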

Compound 4, half-life: > 1 h
Compound 4: only a limit was reported; the forecaster's own chance of this, stated with the estimate: 40%; middle value at least 1.1-fold (0.04 log units) away from the limit.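

Within the data shown here, no step from compound 3 to compound 4 can be read, as both report only a limit: the limit of > 1 h in this assay, at which 2 of the 4 values shown sit. The compounds shown leave open how far either half-life extends past that limit, and so how the two amide nitrogen substituents compare.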